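A Fluorine for a Methyl on the Benzyl Amide

This account rests on a few compounds, and the source may have more. Where it says the series, first, only, none or still open, it means among the compounds named here.

Three compounds share one core and differ only in the group on the amide-type nitrogen. Compound 1 `C=CC1=C(C(=O)Nc2ccc(OCC)cc2)C(c2ccc(OC)cc2)OC1` carries a 4-ethoxyphenyl there. In a functional assay on QGY7701 cells (Homo sapiens) for cytotoxicity, read by MTT assay, with a stated time of 24 h (on this read-out higher numbers stand for weaker inhibition and lower numbers for stronger inhibition), compound 1 gives > 100000 nM, a limit of the assay rather than a number. Compound 2 `C=CC1=C(C(=O)NC2CCCCC2)C(c2ccc(OC)cc2)OC1` carries a cyclohexyl. In this assay compound 2 gives > 100000 nM, again a limit. Among the compounds with values here, compound 3 `C=CC1=C(C(=O)NCc2ccc(C)cc2)C(c2ccc(OC)cc2)OC1` carries a 4-methylbenzyl, and in this assay compound 3 gives 43100 nM, the only value among the three that is a number. Because of the limit of > 100000 nM in this assay, at which 2 of the 3 values shown sit, the step that the two limits leave unreadable from compound 1 to compound 2 stays unreadable, while an at least 2.3-fold lower number from compound 1 to compound 3 (0.36 log units; beyond the scatter) and an at least 2.3-fold lower number from compound 2 to compound 3 (0.36 log units; beyond the scatter) both run the same way. Compound 4 `C=CC1=C(C(=O)NCc2ccccc2F)C(c2ccc(OC)cc2)OC1` differs from compound 3 by 2-fluorophenyl in place of 4-methylphenyl on a saturated chain carbon bound to an amide-type nitrogen. Within the data shown here, no measured step alters a group on the benzyl itself; the two readable steps swap the whole nitrogen substituent, both ending at compound 3. For compound 4 the expected step is small, a 1.2-fold higher number from compound 3 to compound 4 (0.06 log units; within the scatter), with no clear direction. Compound 4 is therefore estimated at 50000 nM, within 15000 nM to 150000 nM.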

Compound 4, half-maximal inhibitory concentration: > 100000 nM
Compound 4: only a limit was reported (the forecaster's own chance of this, stated with the estimate: 30%); middle value at least 2.0-fold (0.30 log units) from the limit.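

This is the only step shown that alters the benzyl group itself rather than replacing the whole nitrogen substituent, and in this assay it is an at least 2.3-fold higher number from compound 3 to compound 4 (0.36 log units; beyond the scatter). From the compounds shown here alone, the value for compound 4 is a limit of the assay, so the true size of this step stays unknown, but the measurable activity of compound 3 clearly does not come with every benzyl amide. The steps to compound 4 from compound 1 and from compound 2 cannot be read, and the cause is a shared limit: the limit of > 100000 nM in this assay, at which 3 of the 4 values shown sit.

Going by these compounds, what remains open is whether the change depends on losing the methyl, gaining the fluorine or the different place of the group on the ring. A plain benzyl, or a benzyl carrying a chlorine or an amine, would help to separate these possibilities.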